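Solubility at the assay limit: from compound 2 to compound 3

The compounds below may be only part of what the source reports. "The series", "measured", "known", "first", "only" and "open" are said of these compounds alone.

In a physicochemical assay for solubility (on this read-out higher numbers stand for higher solubility and lower numbers for lower solubility), compound 1 `O=C(c1nc2c(C(F)(F)F)cc(-c3ccoc3)cn2c1Cl)N1CCC(N2CCCC2=O)CC1` gives > 500000 nM, which is a limit of the assay and not an exact number. Compound 2 `O=C(c1nc2c(C(F)(F)F)cc(-c3ccoc3)cn2c1Cl)N1CCC(N2CCOC2=O)CC1` gives > 500000 nM, which is also only a limit. The record so far is therefore (the limit of > 500000 nM in this assay, at which 2 of the 2 values shown sit), and compound 2 has no exact place on the scale. For the measured compounds named here, the only measured change is a step that the two limits leave unreadable from compound 1 to compound 2, made by putting 2-oxo-1,3-oxazolidin-3-yl in place of 2-oxopyrrolidin-1-yl on a saturated ring carbon. Compound 3 `CC1(C)COC(=O)N1C1CCN(C(=O)c2nc3c(C(F)(F)F)cc(-c4ccoc4)cn3c2Cl)CC1`, not yet measured, differs from compound 2 at that same place: a group of 8 heavy atoms (5 carbon, 1 nitrogen, 2 oxygen; one five-membered non-aromatic ring with 2 hetero atoms) in place of a group of 6 heavy atoms (3 carbon, 1 nitrogen, 2 oxygen; one five-membered non-aromatic ring with 2 hetero atoms), on a saturated ring carbon. The measured step offers no size to carry over, so no shift beyond the scatter is expected in this assay. The expected change is a number no higher from compound 2 to compound 3 (the limit leaves the size open). For compound 3 the estimated value is 500000 nM, with an expected range from 200000 nM to 1000000 nM.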

Compound 3, solubility: > 500000 nM
Compound 3 gave a limit, no number; the forecaster's own chance of this, stated with the estimate: 65%; the middle value lies on the limit itself.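

For the compounds shown here, no step among compound 1, compound 2 and compound 3 can be read, since each gives only a limit, not a number, in this assay: the limit of > 500000 nM in this assay, at which 3 of the 3 values shown sit. The compounds shown leave open where each true value lies, and whether changing the group on the saturated ring carbon shifts it at all.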